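The compounds below may be only part of what the source reports. "The series", "measured", "known", "first", "only" and "open" are said of these compounds alone.

In an ADME assay on HEK293 cells (Homo sapiens) for cytotoxicity, read by CellTiter-Glo and resazurin assay, with a stated time of 72 h (a higher number here means that more compound is needed for the effect, a lower number that less compound is needed), compound 3 `CCOC(=O)CCCCCOc1cccc(CN(C(=O)c2ccc(-c3cccc4ccccc34)cc2)C(C)C)c1` gives only a limit, > 26000 nM. The other two results of this kind are limits as well: compound 1 `CC(C)N(Cc1cccc(OCCCCCC(=O)O)c1)C(=O)c1ccc(-c2cccc3ccccc23)cc1` gives > 26000 nM, a limit. Compound 2 `COc1cccc(-c2ccc(C(=O)N(Cc3cccc(OCCCCCC(=O)O)c3)C(C)C)cc2)c1` gives > 20900 nM, also a limit. Compound 4 `CCOC(=O)CCCCCOc1cccc(CN(C(=O)c2ccc(-c3cnc(OC)nc3OC)cc2)C(C)C)c1` differs from compound 3 by 2,4-dimethoxypyrimidin-5-yl in place of naphthalen-1-yl on an aromatic carbon. The closest measured comparison is a step that the two limits leave unreadable from compound 1 to compound 2, a change at the same place, while a step that the two limits leave unreadable from compound 1 to compound 3 concerns the other difference within the pair; neither size can be read because both ends sit at the limit of > 20900 nM in this assay, at which 1 of the 3 values shown sits, and (the limit of > 26000 nM in this assay, at which 2 of the 3 values shown sit). With no readable step, no shift beyond the scatter is expected, and the step that the limit leaves unreadable from compound 3 to compound 4 is estimated. Compound 4 is therefore expected to give 30000 nM, between 15000 nM and 60000 nM.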

Compound 4, half-maximal effective concentration: > 26000 nM
Compound 4: a limit, no number; the forecaster's own chance of this, stated with the estimate: 85%; the middle value lies beyond the limit too.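

Compound 3 and compound 4 both end at the same limit of the assay rather than at a number, and the step between them cannot be read. The compounds shown leave open what concentration, if any, would give a half-maximal cytotoxic effect.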